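From isopropyl to cyclopropyl on the shared core

A few compounds are considered here, and "the series" means these few. Any claim that something is new, unique, unknown or untested is made for them only; others in the source may bear on it.

Compound 1 `COc1cccc(N2C(=O)COc3ccc(-c4cnc(OC)c(NS(=O)(=O)c5ccc(F)cc5)c4)cc32)c1`: > 40000 nM
Compound 2 `CC(C)N1C(=O)COc2ccc(-c3cnc(Cl)c(NS(=O)(=O)c4ccc(F)cc4)c3)cc21`: 25500 nM
Compound 3 `Cc1ccc(N2C(=O)COc3ccc(-c4cnc5ccccc5c4)cc32)cc1`: > 40000 nM

In a functional assay on A-375 cells (Homo sapiens) for antiproliferative activity, read by MTT assay, with a stated time of 72 h (a higher number here means a weaker inhibitor, a lower number a stronger inhibitor), compound 1 gives > 40000 nM as a limit of the assay and not a number. Compound 3 likewise gives > 40000 nM as a limit and not a number. Within the data shown here, compound 2 gives 25500 nM as the only true number among the three.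

Among the measured compounds shown here, compound 4 `O=C1COc2ccc(-c3cnc(Cl)c(NS(=O)(=O)c4ccc(F)cc4)c3)cc2N1C1CC1` carries cyclopropyl in place of isopropyl on an amide-type nitrogen in a ring, the one difference from compound 2 (cyclopropyl in place of isopropyl on an amide-type nitrogen in a ring). For the measured compounds named here, no two measured compounds differ in one place, so no measured step sets the size of this swap. In this assay no step beyond the usual scatter is expected, in either direction. The expectation rests on compound 2 (25500 nM) alone. A reading at the limit remains possible for compound 4 (the limit of > 40000 nM in this assay, at which 2 of the 3 values shown sit). The expected outcome is a small change (a 1.0-fold lower number from compound 2 to compound 4 (0.01 log units; within the scatter)). Compound 4 is estimated at 25000 nM with an expected range from 12000 nM to 40000 nM in this series.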

Compound 4, half-maximal inhibitory concentration: 21800 nM
Compound 4: the middle estimate sits 1.1-fold (0.06 log units) above what was measured; the range from low to high includes it.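

In this assay, this position now has its first measured step: a 1.2-fold lower number from compound 2 to compound 4 (0.07 log units; within the scatter). Cyclopropyl in place of isopropyl, with the same count of heavy atoms and one three-membered non-aromatic ring added, therefore leaves the reading on the amide-type nitrogen in a ring within the scatter, so this swap gives no measurable separation between the two compounds. Compound 4 joins compound 2 as a true number rather than a limit of the assay, while the count of limit readings stays as it was: the limit of > 40000 nM in this assay, at which 2 of the 4 values shown sit.

As far as these compounds go, whether a longer chain, such as n-hexyl, or a chain ending in an amine or a carboxylic acid on this nitrogen would give a step beyond the scatter stays open. Among these compounds, the two compounds also show only this one pair of groups, so a wider trend at this position cannot be stated.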